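Adding trifluoromethoxy to compound 2

This account rests on a few compounds, and the source may have more. Where it says the series, first, only, none or still open, it means among the compounds named here.

In an ADME assay on microsomes from liver (Homo sapiens) for metabolic stability, with a stated time of 10 min (a higher number here means that more of the compound is left, a lower number that less of the compound is left), compound 1 (`FC(F)(F)c1ccccc1-c1ccc2[nH]c(C3=NOC4(CCCCC4)C3)nc2c1`) gives 100% and compound 2 (`Fc1ccccc1-c1ccc2[nH]c(C3=NOC4(CCCCC4)C3)nc2c1`) gives 79%, the lower of the two numbers. Compound 3 (`Fc1cccc(OC(F)(F)F)c1-c1ccc2[nH]c(C3=NOC4(CCCCC4)C3)nc2c1`) differs from compound 2 in one place: trifluoromethoxy in place of hydrogen on an aromatic carbon, with trifluoromethoxy in place of hydrogen on an aromatic carbon, ortho to a large group and meta to a fluoro group. Among the measured compounds shown here, the only measured step, a number 21 percentage points lower from compound 1 to compound 2 (beyond the scatter), is modest and swaps trifluoromethyl for fluoro, so it is a loose guide that points upward for the added group. A small rise is expected, a number 11 percentage points higher from compound 2 to compound 3 (beyond the scatter). Compound 3 is estimated at 90%, within a range of 72% to 100%.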

Compound 3, percent of the compound remaining: 100%
Compound 3: middle estimate off by 10 percentage points, on the low side; low and high end bracket the measured number.
By their numbers in this assay, from the lowest: compound 2; then compounds 1 and 3 (each within the scatter of the next).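

This position, on an aromatic carbon ortho to a large group and meta to a fluoro group, takes a new substituent with a clear effect: a number 21 percentage points higher from compound 2 to compound 3 (beyond the scatter) is the step seen in this assay with trifluoromethoxy in place of hydrogen. The earlier step swapped one group for another, whereas this one adds a group at a previously unsubstituted carbon. No available measurement explains the rise.

One added group cannot show whether the rise is specific to trifluoromethoxy. Methoxy, chlorine or an amine at this position could behave differently.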